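The source may hold more compounds than are shown below. What is called first, only, known or untested is meant among the compounds shown, and "the series" means these compounds.

The measured compounds in a functional assay on L1210 cells (Mus musculus) for inhibition (a higher number here means a weaker inhibitor, a lower number a stronger inhibitor), are these. Compound 1 is `CC(=O)CC1C[C@@H](CCCCCCCC#C[C@H](O)COCCOC[C@H](O)c2ccccc2)OC1=O` and gives 21600 nM. Compound 2 is `COc1ccc([C@@H](O)COCCOC[C@@H](O)C#CCCCCCCC[C@@H]2CC(CC(C)=O)C(=O)O2)cc1` and gives 32000 nM. Compound 3 is `CC(=O)CC1C[C@@H](CCCCCCCC#C[C@H](O)COCCOC[C@H](O)c2ccc3ccccc3c2)OC1=O` and gives 3000 nM.

Compound 3 stands lowest of the three numbers, and so is the strongest inhibitor among them: the step of a 7.2-fold lower number from compound 1 to compound 3 (0.86 log units; beyond the scatter) and the step of an 11-fold lower number from compound 2 to compound 3 (1.03 log units; beyond the scatter) both lie beyond the scatter, while the step of a 1.5-fold higher number from compound 1 to compound 2 (0.17 log units; within the scatter) does not.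

Compound 4 is `CCCCN(CCCC)[C@@H](O)COCCOC[C@@H](O)C#CCCCCCCC[C@@H]1CC(CC(C)=O)C(=O)O1`. It differs from compound 3 in one place: dibutylamino in place of naphthalen-2-yl on a saturated chain carbon bound to an oxygen on a saturated carbon and a saturated chain carbon. For the measured compounds named here, no measured step swaps an aromatic group for dibutylamino, so the expectation rests on the two steps that touch the naphthalen-2-yl group. Both of them show that a smaller aromatic group in this place gives a higher number than naphthalen-2-yl. Removing the aromatic ring system altogether is therefore expected to raise the number again, plausibly to around the level of compound 1 or beyond, so the estimated step of a 7.3-fold higher number from compound 3 to compound 4 (0.87 log units; beyond the scatter) is expected to be a rise beyond the scatter. Compound 4 is estimated at 22000 nM, within a range from 6000 nM to 80000 nM.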

Compound 4, half-maximal inhibitory concentration: 2500 nM
For compound 4 the middle estimate is 8.8-fold (0.94 log units) above the measured one; measured number below the stated range.
By their numbers in this assay, from the lowest: compounds 4 and 3 (each within the scatter of the next); then compounds 1 and 2 (each within the scatter of the next).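

In this assay, a ring system proves not to be needed on this saturated chain carbon: a 1.2-fold lower number from compound 3 to compound 4 (0.08 log units; within the scatter) shows that dibutylamino, which has no ring, keeps the number level with that of naphthalen-2-yl. Dibutylamino also clearly outperforms the single-ring groups, as an 8.6-fold lower number from compound 1 to compound 4 (0.94 log units; beyond the scatter) and a 13-fold lower number from compound 2 to compound 4 (1.11 log units; beyond the scatter) show, so the earlier trend towards lower numbers with the larger aromatic group does not extend to compound 4. No measurement shown here accounts for this result.

The compounds shown leave open whether the nitrogen or the two butyl chains matter more. A shorter amine such as diethylamino, or a plain hydrocarbon chain such as octyl with no nitrogen, would help separate the two.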